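The source may report more compounds than this note shows. Statements on the series, on what has been measured and on what is new or still open speak of the compounds shown alone.

Compound 2 `CC(C(=O)NCc1ccc(C(C)(C)C)cc1N1CCCC1)c1ccc(NS(C)(=O)=O)c(F)c1` gives the higher of the two numbers measured in an assay on cells for antagonist activity at transient receptor potential cation channel subfamily V member 1 (Homo sapiens), read by FLIPR and calcium flux, with a stated time of 6 min (on this read-out lower numbers stand for stronger inhibition and higher numbers for weaker inhibition), at 8.1 nM, while compound 1 `CC(C(=O)NCc1ccc(C(C)(C)C)nc1SCc1ccccc1)c1ccc(NS(C)(=O)=O)c(F)c1` gives 4 nM in this assay; the two values show compound 1 with the lower number, a gap beyond the scatter. Compound 3 `CC(C(=O)NCc1ccc(C(C)(C)C)cc1C1CCCCC1)c1ccc(NS(C)(=O)=O)c(F)c1` has not yet been measured in this assay; it differs from compound 2 by cyclohexyl in place of pyrrolidin-1-yl on an aromatic carbon. Within the data shown here, no comparable step among the measured compounds exists, so the expected step is a 1.2-fold higher number from compound 2 to compound 3 (0.09 log units; within the scatter), which is expected to stay within the scatter. Compound 3 is estimated in this assay at 10 nM, between 3 nM and 30 nM.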

Compound 3, inhibition constant: 9.8 nM
Estimate against measurement, compound 3: 1.0-fold (0.01 log units) above, and the stated range covers the measured number.
By their numbers in this assay, from the lowest: compound 1; then compounds 2 and 3 (each within the scatter of the next).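

On an aromatic carbon ortho to a large group, cyclohexyl in place of pyrrolidin-1-yl gives a 1.2-fold higher number from compound 2 to compound 3 (0.08 log units; within the scatter) in this assay for this pair. For these two compounds, then, the nitrogen of pyrrolidin-1-yl and its hydrogen-bond acceptor are not required to keep the number in this range, and a ring of carbon only serves as well. Nothing measured here explains this result. Going by these compounds, whether morpholin-4-yl, a primary amine or a longer alkyl chain at this position would keep the number in this range remains open.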